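N-aryl variation on a shared pyridinyloxy-amide core

This account rests on a few compounds, and the source may have more. Where it says the series, first, only, none or still open, it means among the compounds named here.

Measured so far:
Compound 1 `Cn1c(=O)c(C(=O)Nc2ccc(Oc3ccncc3-c3cccnc3)c(F)c2)nn(-c2cccc(C(F)(F)F)c2)c1=O` in a functional assay on MDA-MB-231 cells (Homo sapiens) for cytotoxicity, read by MTT assay, with a stated time of 72 h (on this read-out lower numbers stand for stronger inhibition and higher numbers for weaker inhibition), gives 3980 nM.
Compound 2 `Cn1c(=O)c(C(=O)Nc2ccc(Oc3ccncc3-c3cccnc3)c(F)c2)nn(-c2ccc(F)c(Cl)c2)c1=O` in this assay gives 11300 nM.

Compound 2 stands with the highest of the two numbers; its nearest neighbour is compound 1, and the step of a 2.8-fold higher number from compound 1 to compound 2 (0.45 log units; beyond the scatter) is modest. Compound 3 `COc1ccc(-n2nc(C(=O)Nc3ccc(Oc4ccncc4-c4cccnc4)c(F)c3)c(=O)n(C)c2=O)c(OC)c1` differs from compound 2 by 2,4-dimethoxyphenyl in place of 3-chloro-4-fluorophenyl on an aromatic nitrogen. Within the data shown here, the only step that bears on this site is a 2.8-fold higher number from compound 1 to compound 2 (0.45 log units; beyond the scatter), which shows that swapping the group on that aromatic nitrogen moves the number by a modest amount, in either direction. Compound 3 is therefore expected to land near compound 2, with the step of a 1.6-fold lower number from compound 2 to compound 3 (0.21 log units; within the scatter) only tentatively pointing to a lower number. The estimate for compound 3 is 7000 nM, within 2500 nM to 20000 nM.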

Compound 3, half-maximal inhibitory concentration: 3270 nM
Compound 3: the middle estimate sits 2.1-fold (0.33 log units) above what was measured, and the stated range covers the measured number.
By their numbers in this assay, from the lowest: compounds 3 and 1 (each within the scatter of the next); then compound 2.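

In this assay, the change to 2,4-dimethoxyphenyl on the aromatic nitrogen gives a 3.5-fold lower number from compound 2 to compound 3 (0.54 log units; beyond the scatter) and so recovers the ground lost in compound 2, while a 1.2-fold lower number from compound 1 to compound 3 (0.09 log units; within the scatter) shows no separation from the 3-(trifluoromethyl)phenyl group. Two differently substituted phenyl groups therefore sit level at this position, with compound 2 alone apart from them. No accompanying measurement accounts for these differences.

Still open, from the compounds shown here alone, is whether a carboxylic acid or an amine on this phenyl ring would move the number further. Going by these compounds, a single methoxy group in place of the two in compound 3 also remains untested here.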